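The source may hold more compounds than are shown below. What is called first, only, known or untested is meant among the compounds shown, and "the series" means these compounds.

Measured so far:
compound 1, `O=C(O)CCC(=O)OCCCCCCSc1ccc([N+](=O)[O-])c2nonc12`, 530 nM
compound 2, `O=C(CCC(=O)OCCCCCCSc1ccc([N+](=O)[O-])c2nonc12)Nc1ccc(F)cc1`, 8570 nM

In an assay on isolated protein for inhibition of glutathione S-transferase P (Homo sapiens), with a stated time of 10 min (a higher number here means a weaker inhibitor, a lower number a stronger inhibitor), compound 2 stands at the highest of the two numbers; its nearest neighbour, compound 1, gives 530 nM. Among the measured compounds shown here, the only known step, a 16-fold higher number from compound 1 to compound 2 (1.21 log units; beyond the scatter), is large. Compound 3, `O=C(CCC(=O)N1CCOCC1)OCCCCCCSc1ccc([N+](=O)[O-])c2nonc12`, differs from compound 2 by morpholin-4-yl in place of (4-fluorophenyl)amino on a carbonyl carbon. Like compound 2, compound 3 lacks the hydroxy on a carbonyl carbon that compound 1 carries, so that step bears only indirectly here, and no measured step tells what this exchange does. The expected step is therefore a 1.4-fold lower number from compound 2 to compound 3 (0.15 log units; within the scatter), within the scatter. Compound 3 is estimated at 6000 nM, ranging from 2000 nM to 20000 nM.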

Compound 3, half-maximal inhibitory concentration: 330 nM
Beside the measured number, compound 3's estimate is 18-fold (1.26 log units) above it, outside the stated range (below it).
By their numbers in this assay, from the lowest: compounds 3 and 1 (each within the scatter of the next); then compound 2.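

On this carbonyl carbon the kind of amide matters: morpholin-4-yl in place of (4-fluorophenyl)amino gives a 26-fold lower number from compound 2 to compound 3 (1.41 log units; beyond the scatter) and shows that the earlier loss can be fully recovered. Morpholin-4-yl in place of hydroxy gives a 1.6-fold lower number from compound 1 to compound 3 (0.21 log units; within the scatter) and so shows that removing the hydroxy does not by itself bring the loss seen with compound 2. Nothing at hand explains the gap between the two amides.

On these data alone, whether a plain phenylamino or a small dimethylamino would follow morpholin-4-yl or (4-fluorophenyl)amino remains open. So does whether piperidin-1-yl, with carbon in place of the morpholine oxygen, would match morpholin-4-yl.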